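A Further Methoxy on an Inactive Compound

This account rests on a few compounds, and the source may have more. Where it says the series, first, only, none or still open, it means among the compounds named here.

In a functional assay on UACC-62 cells (Homo sapiens) for cytotoxicity (a higher number here means a weaker inhibitor of growth, a lower number a stronger inhibitor of growth), two compounds have been measured. Compound 1 `COc1ccc(C23OCC24C(CO)C4Cc2cc(OC)c(OC)cc23)cc1OC` gives > 100000 nM, which is a limit of the assay. Compound 2 `COc1ccc(C23OCC24C2COC(c5cc(OC)c(OC)cc53)C24)cc1OC` gives > 100000 nM, likewise a limit. Going by the values given here, both therefore stand at the limit of > 100000 nM in this assay, at which 2 of the 2 values shown sit, and no step between measured compounds is available. Compound 3 `COc1cc2c(cc1OC)C1(c3cc(OC)c(OC)c(OC)c3)OCC13C1COC2C13` differs from compound 2 by methoxy in place of hydrogen on an aromatic carbon. With compound 2 at > 100000 nM, no change beyond the scatter is expected in either direction. The expected step is a number no higher from compound 2 to compound 3 (the limit leaves the size open). The estimate for compound 3 is 100000 nM, with an expected range of 40000 nM to 200000 nM.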

Compound 3, concentration for 50% growth inhibition: 69200 nM
Compound 3: the middle estimate sits 1.4-fold (0.16 log units) above what was measured; the measured number falls inside the stated range.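

Alone among the three compounds shown, compound 3 gives 69200 nM as a true number and not a limit. At this position, ortho to a methoxy group, methoxy in place of hydrogen gives an at least 1.4-fold lower number from compound 2 to compound 3 (0.15 log units; that floor lies within the scatter) and so shows no change beyond the scatter so far. Going by these compounds, the true size of the step stays unknown, because compound 2 stands at a limit: the limit of > 100000 nM in this assay, at which 2 of the 3 values shown sit.

The compounds shown leave open whether a hydroxyl, an amine or a longer chain at this position would give a lower number in this assay and how far that number might fall.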